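One Fluoro-to-Methoxy Step, Repeated on a Second Core

The compounds below may be only part of what the source reports. "The series", "measured", "known", "first", "only" and "open" are said of these compounds alone.

Compound 1, `Cc1ccc(-c2ccc(F)cc2)n1-c1ccc(-c2nc3ccccc3s2)cc1`: 40000 nM
Compound 2, `COc1ccc(-c2ccc(C)n2-c2ccc(-c3nc4ccccc4s3)cc2)cc1`: 36300 nM
Compound 3, `COc1cc2nc(-c3ccc(-n4c(C)ccc4-c4ccc(F)cc4)cc3)sc2c(OC)c1OC`: 43200 nM

Of the compounds shown here, three have been measured in an ADME assay on MCF-10A cells (Homo sapiens) for cytotoxicity, read by MTT assay, with a stated time of 72 h; on this read-out higher numbers stand for weaker inhibition and lower numbers for stronger inhibition. Compound 2 differs from compound 1 by one change, (methoxy in place of fluoro on an aromatic carbon), and that change made a step of a 1.1-fold lower number from compound 1 to compound 2 (0.04 log units; within the scatter). Compound 3 carries the fluoro substituent of compound 1 on a different core; the difference between the two cores is not broken down here. The values of compound 1 and compound 3 lie within the usual scatter of each other, so nothing can be said about an order between them.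

Compound 4, `COc1ccc(-c2ccc(C)n2-c2ccc(-c3nc4cc(OC)c(OC)c(OC)c4s3)cc2)cc1`, has not yet been measured. It applies the same change to the core of compound 3: methoxy in place of fluoro on an aromatic carbon. The place of the change is described in the same words for both pairs, so this is the same change, not merely one of the same kind.

For this assay the step from compound 3 to compound 4 is expected to be a 1.1-fold lower number from compound 3 to compound 4 (0.03 log units; within the scatter), resting on the earlier step of a 1.1-fold lower number from compound 1 to compound 2 (0.04 log units; within the scatter), which stayed within the scatter. Compound 4 is accordingly estimated at 40000 nM, with a likely range from 20000 nM to 80000 nM.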

Compound 4, half-maximal inhibitory concentration: 43900 nM
Estimate against measurement, compound 4: 1.1-fold (0.04 log units) below; low and high end bracket the measured number.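

On the second core, the step from 4-fluorophenyl to 4-methoxyphenyl in this assay came out as a 1.0-fold higher number from compound 3 to compound 4 (0.01 log units; within the scatter). Set beside the earlier step, it gives no sign that the two cores respond differently to this change: the same change on two cores in this assay, a 1.1-fold lower number (0.04 log units; within the scatter) from compound 1 to compound 2 and a 1.0-fold higher number (0.01 log units; within the scatter) from compound 3 to compound 4, 1.1-fold (0.05 log units) apart, within the scatter of two such steps. This shows only that methoxy in place of fluoro left no readable mark on either of these two cores, so the agreement is between two steps that are both too small to read, and it does not show that a step of real size would carry over from one core to another, or that the same would hold on any further core.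

Only fluoro and methoxy are shown at this place, so it stays open whether an amine, a carboxylic acid or a longer alkoxy chain there would give a step beyond the scatter in this assay. From the compounds shown here alone, it also stays open whether such a step would then be the same on both cores.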